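The source may report more compounds than this note shows. Statements on the series, on what has been measured and on what is new or still open speak of the compounds shown alone.

Three analogues sharing one core have been examined in an assay on isolated protein for inhibition of Amine oxidase [flavin-containing] B (Homo sapiens); a higher number here means a weaker inhibitor, a lower number a stronger inhibitor. Compound 1 `CCN(CCCCOc1ccc(C(=O)/C=C/c2ccc(N(C)C)cc2)c(O)c1)Cc1ccccc1` gives 8900 nM. Compound 2 `CCN(CC)CCCOc1ccc(C(=O)/C=C/c2ccc(N(C)C)cc2)c(O)c1` gives 4100 nM, and the step of a 2.2-fold lower number from compound 1 to compound 2 (0.34 log units; beyond the scatter) connects the two. Compound 3 `CCN(CCCOc1ccc(C(=O)/C=C/c2ccc(N(C)C)cc2)c(O)c1)Cc1ccc(N(C)C)cc1` gives 13700 nM, reached by the step of a 3.3-fold higher number from compound 2 to compound 3 (0.52 log units; beyond the scatter); compound 3 thus stands with the highest number of the three, its gap to compound 1 within the scatter and its gap to compound 2 beyond it. Compound 4 `CCN(CCCOc1ccc(C(=O)/C=C/c2ccc(N(C)C)cc2)c(O)c1)Cc1ccccc1` differs from compound 3 by hydrogen in place of dimethylamino on an aromatic carbon. The step from compound 2 to compound 3 bears on this change, and compound 1 carries the same benzyl group. Compound 4 is therefore expected to fall between those neighbours, near 8000 nM (range 3500 nM to 18000 nM), a modest step of a 1.7-fold lower number from compound 3 to compound 4 (0.23 log units; within the scatter).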

Compound 4, half-maximal inhibitory concentration: 13100 nM
Beside the measured number, compound 4's estimate is 1.6-fold (0.21 log units) below it; low and high end bracket the measured number.
By their numbers in this assay, from the lowest: compound 2; then compounds 1, 4 and 3 (each within the scatter of the next).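

In this assay, removing the dimethylamino group from the benzyl ring gives (a 1.0-fold lower number from compound 3 to compound 4 (0.02 log units; within the scatter)), so this aromatic carbon carries either hydrogen or dimethylamino with no readable difference. The plain phenyl in place of methyl is enough for the weakening (a 3.2-fold higher number from compound 2 to compound 4 (0.50 log units; beyond the scatter)), while the longer chain of compound 1 makes no readable difference (a 1.5-fold higher number from compound 1 to compound 4 (0.17 log units; within the scatter)). No outside measurement is available to explain these results. From the compounds shown here alone, whether a methoxy group, a fluorine atom or a carboxylic acid on that same carbon would also leave the number unchanged remains open.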